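The source may report more compounds than this note shows. Statements on the series, on what has been measured and on what is new or still open speak of the compounds shown alone.

Measured in a physicochemical assay for solubility, measured as kinetic solubility, with a stated time of 1 h, at pH 7.4; a higher number here means a more soluble compound, a lower number a less soluble compound:

- compound 1 `N#CCCC(=O)NC1=NN(c2ccc(Cl)c(Cl)c2)CC1`: 39000 nM
- compound 2 `O=C(NC1=NN(c2ccc(Cl)c(Cl)c2)CC1)c1cccnn1`: 67000 nM
- compound 3 `O=C(NC1=NN(c2ccc(Cl)c(Cl)c2)CC1)c1ccncc1F`: 36000 nM

These three compounds share a core and differ only in the group on the carbonyl carbon of the amide. Compound 3, at 36000 nM, lies within the scatter of both other compounds: the numbers show a 1.1-fold lower number from compound 1 to compound 3 (0.03 log units; within the scatter) and a 1.9-fold lower number from compound 2 to compound 3 (0.27 log units; within the scatter).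

The next compound to be measured is compound 4 `Cc1ncncc1C(=O)NC1=NN(c2ccc(Cl)c(Cl)c2)CC1`. It keeps the core of compound 3 but carries 4-methylpyrimidin-5-yl in place of 3-fluoropyridin-4-yl on a carbonyl carbon.

Among the compounds with values here, no measured compound contains this new group, so no step tests it directly. The nearest guide is the exchange of one aromatic ring group for another, a 1.9-fold lower number from compound 2 to compound 3 (0.27 log units; within the scatter). Replacing 2-cyanoethyl with a ring group at the same place gave a 1.7-fold higher number from compound 1 to compound 2 (0.24 log units; within the scatter) and a 1.1-fold lower number from compound 1 to compound 3 (0.03 log units; within the scatter). As far as these compounds go, all three changes stayed within the scatter, so no step beyond the scatter is expected here, and the direction remains open. The expected change is a 1.3-fold higher number from compound 3 to compound 4 (0.10 log units; within the scatter).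

For compound 4, the estimated value is 45000 nM, with an expected range from 20000 nM to 90000 nM.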

Compound 4, solubility: 12000 nM
The estimate for compound 4 lay 3.8-fold (0.57 log units) above the measured number; the measured number lies below the stated range.
By their numbers in this assay, from the lowest: compound 4; then compounds 3, 1 and 2 (each within the scatter of the next).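

In this assay the group on the carbonyl carbon now makes a difference beyond the scatter, which none of the earlier exchanges at this place did: 4-methylpyrimidin-5-yl gives a 3.0-fold lower number from compound 3 to compound 4 (0.48 log units; beyond the scatter) and also a 5.6-fold lower number from compound 2 to compound 4 (0.75 log units; beyond the scatter) and a 3.3-fold lower number from compound 1 to compound 4 (0.51 log units; beyond the scatter) at the same place. Compound 4 therefore has the lowest number of the four, while compound 1, compound 2 and compound 3 remain within the scatter of one another. Two groups that are each one six-membered aromatic ring are thus not interchangeable here, even though 3-fluoropyridin-4-yl and 4-methylpyrimidin-5-yl have the same number of heavy atoms, and nothing shown here explains the difference.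

The exchange from compound 3 to compound 4 removes a fluorine, adds a methyl and adds a ring nitrogen at once, so the compounds shown leave open which of these changes carries the step. Within the data shown here, a pyrimidin-5-yl group without the methyl, or a 4-methylpyridin-3-yl group with only one ring nitrogen, would separate those changes at this place on the carbonyl carbon.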